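Chain methylation of the propyl linker in compound 1

A few compounds are considered here, and "the series" means these few. Any claim that something is new, unique, unknown or untested is made for them only; others in the source may bear on it.

Compound 1 `O=c1oc2ncccc2n1CCCN1CCN(c2ccc(F)cc2)CC1` is the higher of the two measured compounds in a functional assay on the whole organism for inhibition, with Mus musculus as the target, in the writhing test, at a dose of 50 mg/kg by the oral route; on this read-out higher numbers stand for more inhibition at the one dose given (going by the name of the read-out) and lower numbers for less inhibition: in this assay compound 1 gives 85%. Among the measured compounds shown here, its only measured neighbour is compound 2 `COc1ccc(N2CCN(CCCn3c(=O)oc4ncccc43)CC2)cc1`, which in this assay gives 35%, the change being a number 50 percentage points lower from compound 1 to compound 2 (beyond the scatter). That step concerns the substituent on the aromatic ring, not the linker.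

Compound 3 `CC(CN1CCN(c2ccc(F)cc2)CC1)Cn1c(=O)oc2ncccc21` differs from compound 1 by methyl in place of hydrogen on a saturated chain carbon bound to two saturated chain carbons. For the measured compounds named here, no measured step touches a saturated chain carbon bound to two saturated chain carbons, so the single known step offers no direct guidance, and the starting point of compound 1 lies near the top of the read-out, which leaves little room upward. The expectation is therefore a step no larger than the scatter: a number 10 percentage points lower from compound 1 to compound 3 (within the scatter) is the estimated change. Compound 3 is estimated at 75% in this assay, within a range from 50% to 90%.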

Compound 3, a percentage reported as inhibition, in the whole organism at one dose (the size of the read-out at that dose, not a potency): 99%
For compound 3 the middle estimate is 24 percentage points below the measured one; the measured number lies above the stated range.
By their numbers in this assay, from the lowest: compound 2; then compound 1; then compound 3.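

In this assay, methyl in place of hydrogen on a saturated chain carbon bound to two saturated chain carbons raises the number rather than lowering it: a number 14 percentage points higher from compound 1 to compound 3 (beyond the scatter). Among the compounds shown here, this is the first measured change on the linker rather than on the aromatic ring, and it shows that this chain carbon accepts a methyl without loss, with compound 3 at 99%. Nothing in the available data bears on why the methyl has this effect.

Still open, on these data alone, is whether a group larger than methyl at this carbon, such as ethyl or a hydroxymethyl, or a longer chain in place of the propyl linker, would hold the number. Also open, as far as these compounds go, is whether the step of a number 50 percentage points lower from compound 1 to compound 2 (beyond the scatter) would recur with methoxy on the methylated chain.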